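Replacing an Acetoxy Tail with a Thiophenyl Sulfanyl Group

The compounds below may be only part of what the source reports. "The series", "measured", "known", "first", "only" and "open" are said of these compounds alone.

Of the compounds shown here, three share a common core and have been tested in an ADME assay on L02 cells (Homo sapiens) for cytotoxicity, read by MTT assay, with a stated time of 48 h; on this read-out higher numbers stand for weaker inhibition and lower numbers for stronger inhibition. Compound 1 `O=C1O[C@@H](CN2CCCCC2)CN1c1ccc(-n2cc(-c3ccccn3)cn2)c(F)c1` carries a piperidin-1-yl group on the chain carbon; in this assay compound 1 reaches only the limit > 400 ug/mL. Compound 2 `O=C1O[C@@H](CN2CCC(O)CC2)CN1c1ccc(-n2cc(-c3ccccn3)cn2)c(F)c1` adds a hydroxy group to that ring, and in this assay compound 2 likewise stops at the limit > 400 ug/mL. Compound 3 `CC(=O)OC[C@H]1CN(c2ccc(-n3cc(-c4ccccn4)cn3)c(F)c2)C(=O)O1` carries an acetoxy group in place of the ring, and in this assay compound 3 again shows only the limit > 400 ug/mL. Because every value sits at the limit of > 400 ug/mL in this assay, at which 3 of the 3 values shown sit, the steps a step that the two limits leave unreadable from compound 1 to compound 2, a step that the two limits leave unreadable from compound 1 to compound 3 and a step that the two limits leave unreadable from compound 2 to compound 3 cannot be sized; compound 3 therefore stands level with the others at the limit, with no number of its own.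

Compound 4 `O=C1O[C@@H](CSc2cccs2)CN1c1ccc(-n2cc(-c3ccccn3)cn2)c(F)c1` differs from compound 3 by (thiophen-2-yl)sulfanyl in place of acetoxy on a saturated chain carbon bound to a saturated ring carbon. Going by the values given here, none of the measured steps gives a readable size, so there is no basis for expecting a shift beyond the scatter in this assay. Compound 4 is expected to give about 300 ug/mL, between 100 ug/mL and 600 ug/mL, which means an expected step of an at least 1.3-fold lower number from compound 3 to compound 4 (0.12 log units; that floor lies within the scatter) from compound 3.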

Compound 4, half-maximal inhibitory concentration: > 400 ug/mL
Compound 4 was reported as a limit; the forecaster's own chance of this, stated with the estimate: 60%; middle value at least 1.3-fold (0.12 log units) from the limit.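

Compound 4 also gives only a limit, so no step linking it to compound 1, compound 2 or compound 3 can be read, because all four compounds stop at the same value: the limit of > 400 ug/mL in this assay, at which 4 of the 4 values shown sit.

The compounds shown leave open what actual number each would reach in this assay, and whether changing the group on the chain carbon shifts that number at all.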